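This account rests on a few compounds, and the source may have more. Where it says the series, first, only, none or still open, it means among the compounds named here.

Compound 3 `Cn1cncc1CN1CC(N(CC2CCN(C(=O)CC(C)(C)C)CC2)S(=O)(=O)c2ccccn2)Cc2cc(C#N)ccc21` was tested in an ADME assay on Caco-2 cells (Homo sapiens) for permeability, in the apical to basolateral direction (a higher number here means that the compound crosses the layer faster, a lower number that the compound crosses the layer more slowly), and compound 3 gives 0.5 10^-6 cm/s. That puts it level with compound 1 `C=C(C)C(=O)N1CCC(CN(C2Cc3cc(C#N)ccc3N(Cc3cncn3C)C2)S(=O)(=O)c2ccccn2)CC1`, which in this assay gives 0.5 10^-6 cm/s, and together those two are the lowest of the three numbers. Compound 2 `Cc1noc(C)c1CN(C1Cc2cc(C#N)ccc2N(Cc2cncn2C)C1)S(=O)(=O)c1ccccn1` gives 8 10^-6 cm/s, the step being a 16-fold higher number from compound 1 to compound 2 (1.20 log units; beyond the scatter). Compound 4 `CCNC(=O)N1CCC(CN(C2Cc3cc(C#N)ccc3N(Cc3cncn3C)C2)S(=O)(=O)c2ccccn2)CC1` has not yet been measured. Compared with compound 3 the change is ethylamino in place of neopentyl on a carbonyl carbon. Of the two measured steps, a 16-fold higher number from compound 1 to compound 2 (1.20 log units; beyond the scatter) replaces the entire group on the saturated chain carbon bound to the sulfonamide nitrogen, a part that stays the same in compound 4, so it does not bear on this case. The step of no change at the digits printed from compound 1 to compound 3 (within the scatter) alters only the group on the carbonyl carbon, exactly the place changed in compound 4. On that evidence the expected step of no change at the digits printed from compound 3 to compound 4 (within the scatter) is none beyond the scatter. Compound 4 is therefore estimated at 0.5 10^-6 cm/s, with a range from 0.2 10^-6 cm/s to 1.2 10^-6 cm/s.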

Compound 4, apparent permeability: 0.6 10^-6 cm/s
Compound 4: the middle estimate sits 1.2-fold (0.08 log units) below what was measured; low and high end bracket the measured number.
By their numbers in this assay, from the lowest: compounds 1, 3 and 4 (each within the scatter of the next); then compound 2.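

Putting ethylamino in place of neopentyl on this carbonyl carbon brings in a nitrogen and a hydrogen-bond donor, and in this assay the step is a 1.2-fold higher number from compound 3 to compound 4 (0.08 log units; within the scatter). Ethylamino in place of 1-methylethenyl gives a 1.2-fold higher number from compound 1 to compound 4 (0.08 log units; within the scatter), so all three groups tested at this place lie within the scatter of one another. Exchanging the whole group, with 1-(ethylcarbamoyl)piperidin-4-yl in place of 3,5-dimethyl-1,2-oxazol-4-yl, again gives a large step, a 13-fold lower number from compound 2 to compound 4 (1.12 log units; beyond the scatter), and no available measurement offers an explanation for either result.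

As far as these compounds go, it remains open whether a chain ending in a carboxylic acid on this carbonyl carbon would shift the number beyond the scatter. Also open, from the compounds shown here alone, is whether a piperidin-4-yl with a free amine, carrying no carbonyl group, would fall nearer compound 2 or compound 4.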